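Adding One Chloro Group to Compound 3

This account rests on a few compounds, and the source may have more. Where it says the series, first, only, none or still open, it means among the compounds named here.

In a functional assay on MCF7 cells (Homo sapiens) for inhibition, read by MTT assay, with a stated time of 48 h, tested at 10 uM (on this read-out higher numbers stand for more inhibition of growth at the one concentration tested and lower numbers for less inhibition of growth), compound 1 `Cc1cc(=O)c2c(O)cc(OCc3ccc(Br)cc3)c([C@H]3CCN(C)C[C@H]3O)c2o1` gives 14% of inhibition, compound 2 `Cc1cc(=O)c2c(O)cc(O)c([C@H]3CCN(C)C[C@H]3OC(=O)c3ccco3)c2o1` gives 20% of inhibition, and compound 3 `CN1CC[C@H](c2c(O)cc(O)c3c(=O)cc(/C=C/c4ccccc4)oc23)[C@H](O)C1` gives 8% of inhibition. Compound 3 and compound 1 lie within the usual scatter of repeated measurements, so they cannot be told apart, and the same holds for compound 1 and compound 2. Only the gap between compound 3 and compound 2 goes beyond the scatter, with compound 3 on the lower side.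

Compound 4 `CN1CC[C@H](c2c(O)cc(O)c3c(=O)cc(/C=C/c4ccccc4Cl)oc23)[C@H](O)C1` differs from compound 3 in one place chloro in place of hydrogen on an aromatic carbon and turns phenyl to 2-chlorophenyl, with chloro in place of hydrogen on an aromatic carbon, ortho to a large group. Within the data shown here, no two tested compounds differ in just one place, so the data give no direct measure of such a change. In this assay the expected step is small and slightly upward, with none beyond the scatter. That expectation rests on the narrow spread so far, with compound 3 at 8% of inhibition and compound 2 at 20% of inhibition. The estimated change a number 4 percentage points higher from compound 3 to compound 4 (within the scatter) therefore stays modest. Compound 4 is estimated at 12% of inhibition, within an expected range from 3% to 25% of inhibition.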

Compound 4, percent growth inhibition at one concentration: 63%
Estimate against measurement, compound 4: 51 percentage points below; the measured number lies above the stated range.
By their numbers in this assay, from the lowest: compounds 3, 1 and 2 (each within the scatter of the next, the first and the last beyond it); then compound 4.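

Turning phenyl to 2-chlorophenyl gives a number 55 percentage points higher from compound 3 to compound 4 (beyond the scatter) in this assay, and this is the only step shown between two tested compounds that differ in one place. It shows that an aromatic carbon ortho to a large group can be a sensitive place on this molecule: a single chlorine atom in place of hydrogen moves the read-out far more than the earlier values, which stayed in a narrow band, gave any reason to expect. No measurement shown here says what lies behind this large step.

What stays open is whether the gain belongs to chloro in particular or would also come with another group on the same carbon, such as fluoro, methyl or methoxy, as only hydrogen and chloro are shown there. Also open, going by these compounds, is whether chloro on other carbons of this ring would give a step of similar size, and whether the same change would carry over to compounds lacking the 2-phenylethenyl group, such as compound 1 and compound 2.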